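Fluorines in Place of Methoxy on the Chalcone Ketone

A few compounds are considered here, and "the series" means these few. Any claim that something is new, unique, unknown or untested is made for them only; others in the source may bear on it.

The series rests on three measured compounds and one that still awaits its number in a functional assay on T47D cells (Homo sapiens) for inhibition, read by sulforhodamine B assay, with a stated time of 48 h; on this read-out lower numbers stand for higher toxicity in this test and higher numbers for lower toxicity in this test. Compound 1 `COc1ccc(-c2cc(/C=C/C(=O)c3ccc(OC)c(OC)c3)[nH]n2)cc1` in this assay gives 24900 nM. Compound 2 `COc1ccc(-c2cc(/C=C/C(=O)c3cc(OC)c(OC)c(OC)c3)[nH]n2)cc1OC` reaches only a limit of the assay, reported as > 100000 nM. Compound 3 `COc1ccc(C(=O)/C=C/c2cc(-c3cc(OC)c(OC)c(OC)c3)n[nH]2)cc1` likewise returns a limit and no number, > 100000 nM. Compound 3 therefore stands at the weak end of what is shown, sharing its position with compound 2; this is the limit of > 100000 nM in this assay, at which 2 of the 3 values shown sit, and only compound 1 lies below it with a real value. Among the compounds with values here, no pair among the measured compounds differs in a single place, so no measured step is available to lean on.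

Compound 4 `COc1cc(-c2cc(/C=C/C(=O)c3ccc(F)c(F)c3)[nH]n2)cc(OC)c1OC` follows from compound 3 through (3,4-difluorophenyl in place of 4-methoxyphenyl on a carbonyl carbon). The remaining part of the molecule is unchanged. Within the data shown here, nothing measured tells how such an exchange on this carbonyl carbon acts in this assay; compound 1, the only compound with a real number, differs from compound 3 in more than one place. The step from compound 3 to compound 4 is expected to be modest, an at least 1.6-fold lower number from compound 3 to compound 4 (0.22 log units; that floor lies within the scatter), in the direction of higher toxicity, but within broad uncertainty. Compound 4 is thus estimated at 60000 nM, with a range from 15000 nM to 200000 nM, and a real chance that only a limit is reported again.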

Compound 4, concentration lethal to 50% of the cells: > 100000 nM
Compound 4: no number, only a limit; the forecaster's own chance of this, stated with the estimate: 45%; middle value at least 1.6-fold (0.22 log units) away from the limit.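

In this assay compound 3 and compound 4 both return only a limit and no number, so no step can be read between them. The weak end of the series gains one more compound: the limit of > 100000 nM in this assay, at which 3 of the 4 values shown sit. The compounds shown leave open whether 3,4-difluorophenyl in place of 4-methoxyphenyl on a carbonyl carbon changes toxicity in this test at all.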